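This account rests on a few compounds, and the source may have more. Where it says the series, first, only, none or still open, it means among the compounds named here.

The series is compared in a functional assay on HEK293 cells for negative allosteric modulation of metabotropic glutamate receptor 5 (Rattus norvegicus), read by FLIPR and calcium flux, with a stated time of 170 s; a lower number here means a stronger inhibitor, a higher number a weaker inhibitor. Compound 2 `c1ccc(-c2cc3n(n2)CCCC3)cc1` gives 1900 nM. Compound 3 `Clc1cccc(-c2cc3n(n2)CCCC3)c1` gives 77 nM, and the step of a 25-fold lower number from compound 2 to compound 3 (1.39 log units; beyond the scatter) comes from a single change, (chloro in place of hydrogen on an aromatic carbon). Compound 1 `N#Cc1ccc(CC(=O)c2cc3n(n2)CCCC3)nc1` gives 53 nM; the difference between its core and that of compound 2 is not broken down here, and its value lies within the scatter of that of compound 3.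

The untested compound 4 `N#Cc1ccc(CC(=O)c2nn3c(c2Cl)CCCC3)nc1` carries a change of the same kind as that from compound 2 to compound 3, namely (chloro in place of hydrogen on an aromatic carbon). The place, however, is not the same: in compound 3 the chloro stands on a six-membered aromatic ring of carbon only, meta to a group of 9 heavy atoms, whereas in compound 4 it enters a five-membered aromatic ring with 2 nitrogen, part of a fused system, next to the ring atom that bears a fused ring and next to the ring atom that bears a large group. Among the measured compounds shown here, no measured pair shows a chloro at that place, so the large step seen from compound 2 to compound 3 cannot simply be carried over. The step from compound 1 to compound 4 in this assay is therefore expected to be small, a 1.2-fold lower number from compound 1 to compound 4 (0.07 log units; within the scatter), with wide uncertainty. Compound 4 is estimated at 45 nM, between 10 nM and 200 nM.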

Compound 4, half-maximal inhibitory concentration: 108 nM
For compound 4 the middle estimate is 2.4-fold (0.38 log units) below the measured one; the measured number falls inside the stated range.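

In this assay, chloro in place of hydrogen on an aromatic carbon gives a 2.0-fold higher number from compound 1 to compound 4 (0.31 log units; beyond the scatter), a modest step that runs opposite in direction to the large one seen on the other core. The effect of this change therefore does not carry over from one core to the other among these compounds, as the two steps differ in both direction and size: the same change on two cores in this assay, a 25-fold lower number (1.39 log units; beyond the scatter) from compound 2 to compound 3 and a 2.0-fold higher number (0.31 log units; beyond the scatter) from compound 1 to compound 4, 50-fold (1.70 log units) apart, beyond the scatter of two such steps The two pairs differ in the core and also in the place of the chloro, so they do not show which of the two matters, and they give no cause for the reversal.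

The compounds shown leave open how other groups, such as a fluoro, a bromo, a methyl or an amine, would behave on the aromatic carbon of the five-membered aromatic ring with 2 nitrogen in the core of compound 1. They also leave open whether those groups would follow the step seen with chloro.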